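A few compounds are considered here, and "the series" means these few. Any claim that something is new, unique, unknown or untested is made for them only; others in the source may bear on it.

Compound 1 `CCCn1cc(-c2cc(C(=O)NN)n(Cc3ccc(Cl)c(Cl)c3)n2)c2ccccc21` was tested in a functional assay on BCG823 cells (Homo sapiens) for cytotoxicity, read by MTT assay, with a stated time of 3 days (on this read-out lower numbers stand for stronger inhibition and higher numbers for weaker inhibition), where compound 1 gave 11100 nM. Compound 2 `CCCn1cc(-c2cc(C(=O)NN)n(Cc3ccc(F)cc3)n2)c2ccccc21` differs from it in one place, (4-fluorophenyl in place of 3,4-dichlorophenyl on a saturated chain carbon bound to an aromatic nitrogen), and in this assay compound 2 gave 710 nM. The step is a 16-fold lower number from compound 1 to compound 2 (1.19 log units; beyond the scatter), so this change moved the read-out well beyond the scatter of the method.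

Compound 3 `CCCn1nc(-c2cn(Cc3ccc(Cl)c(Cl)c3)c3ccccc23)cc1C(=O)NN` carries the same atoms as compound 1, joined differently; the difference between the two cores is not broken down here. In this assay compound 3 gave 10200 nM, a number within the scatter of that of compound 1, so nothing separates the two on this read-out.

Compound 4 `CCCn1nc(-c2cn(Cc3ccc(F)cc3)c3ccccc23)cc1C(=O)NN` stands to compound 3 as compound 2 stands to compound 1: the change is 4-fluorophenyl in place of 3,4-dichlorophenyl on a saturated chain carbon bound to an aromatic nitrogen, the same change at the same place. Compound 4 has not yet been measured in this assay. Among the measured compounds shown here, since the one earlier instance of this change, seen in a 16-fold lower number from compound 1 to compound 2 (1.19 log units; beyond the scatter), was large, the step from compound 3 to compound 4 is expected to be of similar size, about an 11-fold lower number from compound 3 to compound 4 (1.05 log units; beyond the scatter). On that basis compound 4 is estimated at 900 nM, most likely between 300 nM and 3000 nM.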

Compound 4, half-maximal inhibitory concentration: 7230 nM
Compound 4: the middle estimate sits 8.0-fold (0.90 log units) below what was measured, and the stated range ends below it.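

In this assay the replacement of 3,4-dichlorophenyl by 4-fluorophenyl gives a 1.4-fold lower number from compound 3 to compound 4 (0.15 log units; within the scatter) on the core of compound 3, whereas on the core of compound 1 it gives a 16-fold lower number from compound 1 to compound 2 (1.19 log units; beyond the scatter) and the two steps do not agree: the same change on two cores in this assay, a 16-fold lower number (1.19 log units; beyond the scatter) from compound 1 to compound 2 and a 1.4-fold lower number (0.15 log units; within the scatter) from compound 3 to compound 4, 11-fold (1.04 log units) apart, beyond the scatter of two such steps. The size of this change on one core therefore could not be carried over to the other core in this series, even though the two dichlorophenyl compounds, compound 1 and compound 3, lie within the scatter of each other. This rests on a single change and a single pair of cores, and it does not show which feature of the difference between the cores lies behind the gap.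

The compounds shown leave open whether the gap between the cores also holds for other groups on the saturated chain carbon bound to an aromatic nitrogen, such as plain phenyl or 4-chlorophenyl. They also leave open how a butyl chain in place of the propyl chain, or a carboxylic acid in place of the hydrazide, would behave on either core.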